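The compounds below may be only part of what the source reports. "The series", "measured", "known", "first", "only" and "open" are said of these compounds alone.

In a functional assay on MCF7 cells (Homo sapiens) for cytotoxicity, read by MTT assay, with a stated time of 4 days (on this read-out lower numbers stand for stronger inhibition and higher numbers for weaker inhibition), compound 1 `C=C1C[C@]23C[C@@]1(O)CC[C@H]2c1ccc(OS(=O)(=O)c2ccc(C)cc2)c(C)c1[C@@H]3Cn1cc(-c2ccc(Cl)cc2)nn1` reaches only the limit of the assay, > 20000 nM; this is a limit, not a measured number, and it matches (the limit of > 20000 nM in this assay, at which 2 of the 3 values shown sit). Compound 2 `C=C1C[C@]23C[C@@]1(O)CC[C@H]2c1ccc(O)c(C)c1[C@@H]3Cn1cc(-c2ccc(C(F)(F)F)cc2)nn1` in this assay gives 12400 nM. Compound 3 `C=C1C[C@]23C[C@@]1(O)CC[C@H]2c1cc(Br)c(O)c(C)c1[C@@H]3Cn1cc(-c2ccc(OC)cc2)nn1` also stops at the limit of this assay, > 20000 nM. Compound 1 therefore stands at the limit, with no number of its own. The change from compound 1 to compound 4 `C=C1C[C@]23C[C@@]1(O)CC[C@H]2c1ccc(OS(=O)(=O)c2ccc(C)cc2)c(C)c1[C@@H]3Cn1cc(-c2ccc(C)cc2)nn1` is methyl in place of chloro on an aromatic carbon. No step between measured compounds is shown, so the expectation rests on the limit of compound 1 alone, and a step of a number no higher from compound 1 to compound 4 (the limit leaves the size open) no larger than the scatter is expected, most likely ending again at a limit. Compound 4 is estimated at 20000 nM, between 10000 nM and 40000 nM.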

Compound 4, half-maximal inhibitory concentration: > 20000 nM
Compound 4 ended at the assay's limit; the forecaster's own chance of this, stated with the estimate: 65%; the middle value sits exactly at the limit.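

No step can be read from compound 1 to compound 4, since both stop at a limit rather than a number: the limit of > 20000 nM in this assay, at which 3 of the 4 values shown sit.

The compounds shown leave open whether methyl in place of chloro changes cytotoxicity at all.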